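This account rests on a few compounds, and the source may have more. Where it says the series, first, only, none or still open, it means among the compounds named here.

Compound 3 `COc1cc(C)c(Cl)c2c1C(=O)C=CC2=O` gives 20600 nM in a functional assay on MCF7 cells (Homo sapiens) for cytotoxicity, read by XTT assay, with a stated time of 24 h; a lower number here means a stronger inhibitor, a higher number a weaker inhibitor. Among the three measured compounds it stands second highest: compound 2 `Cc1cc(O)c2c(c1Cl)C(=O)C=CC2=O` gives 15700 nM, and compound 1 `CCOc1cc(C)c(Cl)c2c1C(=O)C=CC2=O` gives 40000 nM, yet both of these neighbours lie within the scatter of compound 3.

Compound 4 `CC(=O)Oc1cc(C)c(Cl)c2c1C(=O)C=CC2=O` differs from compound 3 at a single site: acetyl in place of methyl on an oxygen on an aromatic ring. The measured steps that bear on this position all concern the group on that same oxygen on an aromatic ring. The step of a 1.9-fold lower number from compound 1 to compound 3 (0.29 log units; within the scatter) and the step of a 1.3-fold higher number from compound 2 to compound 3 (0.12 log units; within the scatter) each stay within the scatter, while the step of a 2.5-fold lower number from compound 1 to compound 2 (0.41 log units; beyond the scatter) is the only one that reaches beyond it, and only modestly. For the measured compounds named here, an acetyl has not been placed there, so no step speaks to it directly; what the nearby steps show is that exchanging one small group for another on this oxygen has moved this assay little.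

Compound 4 is therefore expected to stay close to compound 3, with an expected step of a 1.0-fold lower number from compound 3 to compound 4 (0.01 log units; within the scatter) that does not clear the scatter. The estimated value of compound 4 is 20000 nM, within a range from 8000 nM to 50000 nM.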

Compound 4, half-maximal inhibitory concentration: 37900 nM
Beside the measured number, compound 4's estimate is 1.9-fold (0.28 log units) below it, within the range that was stated.
By their numbers in this assay, from the lowest: compounds 2, 3, 4 and 1 (each within the scatter of the next, the first and the last beyond it).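

In this assay, compound 4 brings the first acetyl onto this oxygen on an aromatic ring, and the methoxy to acetoxy exchange stays within the scatter (a 1.8-fold higher number from compound 3 to compound 4 (0.26 log units; within the scatter)), as does the exchange of ethyl for acetyl (a 1.1-fold lower number from compound 1 to compound 4 (0.02 log units; within the scatter)). Only the comparison with the free hydroxyl compound clears the scatter, and only modestly (a 2.4-fold higher number from compound 2 to compound 4 (0.38 log units; beyond the scatter)), so compound 2 now stands apart from both compound 1 and compound 4, although compound 3 goes against any clean split because it lies within the scatter of all three. The added carbonyl, with its extra hydrogen-bond acceptor, thus brought no step beyond the scatter against either ether on this oxygen, but nothing shown here explains why the numbers fall as they do.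

The compounds shown leave open how a longer acyl chain, a chain ending in an amine or one ending in a carboxylic acid on this oxygen would read in this assay. From the compounds shown here alone, every compound also keeps the rest of the shared core unchanged, so it remains open whether these small steps would hold if the chlorine or the methyl on the core were replaced.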